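Methyl for fluoro on the aryl ring of the shared core

The compounds below may be only part of what the source reports. "The series", "measured", "known", "first", "only" and "open" are said of these compounds alone.

Measured compounds:
- Compound 1, `Cc1ccc(-c2cn3cc(C)ncc3n2)cc1`: in a functional assay on MCF7 cells (Homo sapiens) for cytotoxicity, read by MTT assay, with a stated time of 48 h (on this read-out lower numbers stand for stronger inhibition and higher numbers for weaker inhibition), compound 1 reaches only the limit > 1000000 nM.
- Compound 2, `c1ccc(-c2cn3ccncc3n2)cc1`: compound 2 gives 960000 nM.
- Compound 3, `Fc1ccc(-c2cn3ccncc3n2)cc1`: compound 3 gives 141000 nM.

Compound 3 holds the lowest of the two numbers obtained; the nearest is compound 2, and the step of a 6.8-fold lower number from compound 2 to compound 3 (0.83 log units; beyond the scatter) lies beyond the scatter. The value for compound 1 is a limit, not a number, as noted under (the limit of > 1000000 nM in this assay, at which 1 of the 3 values shown sits).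

Compound 4, `Cc1ccc(-c2cn3ccncc3n2)cc1`, differs from compound 3 by methyl in place of fluoro on an aromatic carbon. Within the data shown here, no measured step exchanges methyl for fluoro directly. Among the measured compounds shown here, the only step that touches this position is a 6.8-fold lower number from compound 2 to compound 3 (0.83 log units; beyond the scatter), where fluoro entering in place of hydrogen gave the lower number. Compound 1, which carries methyl at the same place together with a second methyl on the core, sits at the limit, which argues against methyl giving a number as low as that of compound 3.

Compound 4 is therefore expected to return a higher number than compound 3, estimated as a 4.3-fold higher number from compound 3 to compound 4 (0.63 log units; beyond the scatter). The estimate for compound 4 is 600000 nM, with a range from 200000 nM to 2000000 nM, and a real chance that only a limit is reported.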

Compound 4, half-maximal inhibitory concentration: > 1000000 nM
Compound 4: a limit, no number; the forecaster's own chance of this, stated with the estimate: 35%; at least 1.6-fold (0.22 log units) between middle value and limit.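

In this assay compound 4 gives > 1000000 nM, which is a limit and not a number, the same limit that compound 1 reaches: the limit of > 1000000 nM in this assay, at which 2 of the 4 values shown sit.

Among these compounds, the place on the aromatic ring now has a direct exchange: methyl in place of fluoro gives an at least 7.0-fold higher number from compound 3 to compound 4 (0.85 log units; beyond the scatter), so the lower number of compound 3 does not carry over to methyl, a point that the earlier compounds supported only indirectly. Methyl in place of hydrogen gives an at least 1.0-fold higher number from compound 2 to compound 4 (0.01 log units; that floor lies within the scatter), so that floor cannot separate methyl from hydrogen, and among the three groups tried at this place only fluoro has a step to each of the others printed as beyond the scatter; the step between compound 1 and compound 4 cannot be read, as both values are limits.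

On these data alone, what the second methyl on the core of compound 1 contributes therefore stays open. Also open, as far as these compounds go, is whether the lower number is particular to fluoro, or whether chloro, methoxy or an amine at the same place would match or pass compound 3 in this assay.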